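The source may hold more compounds than are shown below. What is called first, only, known or untested is meant among the compounds shown, and "the series" means these compounds.

Compound 1 `CCCCCCCCCCCCCCCCCC/N=c1\nc(N)c2nc[nH]c2c(N)n1` and compound 2 `CCCCCCCCCCCCCCCCCC/N=c1\nc(N)c2ncn(Cc3ccccc3)c2c(N)n1` share a core that carries a long saturated chain on a double-bonded nitrogen. In a functional assay on OVCAR-3 cells (Homo sapiens) for antiproliferative activity, read by WST assay, with a stated time of 72 h (a higher number here means a weaker inhibitor, a lower number a stronger inhibitor), compound 1 gives 3100 nM, and compound 2 gives 4950 nM. Within the data shown here, the only measured step, a 1.6-fold higher number from compound 1 to compound 2 (0.20 log units; within the scatter), adds a benzyl group and leaves the number essentially unchanged. Compound 2 thus stands at the higher of the two numbers, but its gap to compound 1 sits within the scatter, so the two cannot be separated. Compound 3 `CCCCCCCCCC/N=c1\nc(N)c2ncn(Cc3ccccc3)c2c(N)n1` differs from compound 2 only in the chain: hydrogen in place of octyl on a saturated chain carbon, ten or more bonds along the chain from a double-bonded nitrogen. Among the measured compounds shown here, no measured step touches this chain, so the benzyl step gives no guide to how shortening it will read in this assay. Lacking such a guide, compound 3 is expected to show a step of a 1.6-fold higher number from compound 2 to compound 3 (0.21 log units; within the scatter), with wide uncertainty. The estimate for compound 3 is 8000 nM, between 2500 nM and 30000 nM.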

Compound 3, half-maximal inhibitory concentration: 3950 nM
Compound 3: middle estimate off by 2.0-fold (0.31 log units), on the high side, and the stated range covers the measured number.
By their numbers in this assay, from the lowest: compounds 1, 3 and 2 (each within the scatter of the next).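

Among these compounds, this is the first measured change to the long chain, and in this assay hydrogen in place of octyl gives a 1.3-fold lower number from compound 2 to compound 3 (0.10 log units; within the scatter). The numbers for the two compounds cannot be separated, so in this benzyl-bearing pair the octyl part of the chain makes no readable difference to antiproliferative activity. Nothing measured here offers a reason for this result.

This single pair cannot show whether the same holds without the benzyl group, or whether still shorter chains would also leave the number in place. Also open, going by these compounds, is whether an amine or a carboxylic acid at this place on the chain would read differently from hydrogen or octyl.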